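Tail Extension on a Thioether Amide: Expected Cytotoxicity

The source may hold more compounds than are shown below. What is called first, only, known or untested is meant among the compounds shown, and "the series" means these compounds.

Compound 1 `CCN(CC)c1nc(C)c2[nH]c(SCC(=O)NCCN)nc2n1` gives in an ADME assay on CEM174 cells (Homo sapiens) for cytotoxicity; a lower number here means that less compound is tolerated, a higher number that more compound is tolerated > 100 uM, a limit of the assay rather than a number.
Compound 2 `CCN(CC)c1nc(C)c2[nH]c(SCC(=O)NCCCN)nc2n1` gives in this assay > 100 uM, likewise a limit.

Compound 2 thus stands at the limit, where both measured values sit (the limit of > 100 uM in this assay, at which 2 of the 2 values shown sit). The step that the two limits leave unreadable from compound 1 to compound 2 therefore has no readable size. Compound 3 `CCN(CC)c1nc(C)c2[nH]c(SCC(=O)NCCNC(=N)N)nc2n1` differs from compound 2 by a group of 4 heavy atoms (1 carbon, 3 nitrogen; no ring) in place of a group of 2 heavy atoms (1 carbon, 1 nitrogen; no ring), on a saturated chain carbon, two bonds along the chain from an amide-type nitrogen. Among the compounds with values here, since only this unreadable step bears on the change (the limit of > 100 uM in this assay, at which 2 of the 2 values shown sit), compound 3 is expected to show a step that the limit leaves unreadable from compound 2 to compound 3 in this assay, nothing beyond the scatter. The estimate for compound 3 is 120 uM, expected between 50 uM and 300 uM.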

Compound 3, half-maximal toxic concentration: > 100 uM
Compound 3 ended at the assay's limit; the forecaster's own chance of this, stated with the estimate: 85%; the middle value lies beyond the limit too.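

No step among compound 1, compound 2 and compound 3 can be read in this assay, since each value is a limit: the limit of > 100 uM in this assay, at which 3 of the 3 values shown sit.

The compounds shown leave open the actual toxic concentration of each, and whether these tail changes alter it.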